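The compounds below may be only part of what the source reports. "The series", "measured", "known", "first", "only" and "open" are said of these compounds alone.

Measured so far in a functional assay on HeLa cells (Homo sapiens) for inhibition; a higher number here means a weaker inhibitor, a lower number a stronger inhibitor:
- compound 1 `O=C1O/C(=C\Cn2cc(I)c(=O)[nH]c2=O)C(OCc2ccccc2)=C1OCc1ccccc1`: 40000 nM
- compound 2 `O=C1O/C(=C\Cn2cc(Cl)c(=O)[nH]c2=O)C(OCc2ccccc2)=C1OCc1ccccc1`: 30000 nM
- compound 3 `O=C1O/C(=C\Cn2cnc3c(-n4cccc4)ncnc32)C(OCc2ccccc2)=C1OCc1ccccc1`: > 100000 nM (a limit of the assay, not a number)

Going by the values given here, only two true numbers exist so far. Compound 2 stands at 30000 nM, and compound 1 lies within the scatter of it at 40000 nM.

The next step leads to compound 4 `O=C1O/C(=C\Cn2cc(F)c(=O)[nH]c2=O)C(OCc2ccccc2)=C1OCc1ccccc1`, which carries fluoro in place of chloro on an aromatic carbon. The exchange sits on an aromatic carbon of a six-membered aromatic ring with 2 nitrogen, and the rest of the structure is unchanged.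

Among the compounds with values here, one measured step bears on this. Chloro in place of iodo at the same place gave a 1.3-fold lower number from compound 1 to compound 2 (0.12 log units; within the scatter). That single step is the whole basis for the expectation, and it offers no direction to carry over. No step beyond the scatter is therefore expected in this assay, though one step is thin support and the range is kept wide.

The expected change is a 1.1-fold lower number from compound 2 to compound 4 (0.03 log units; within the scatter), which is an estimate and not a measurement.

For compound 4 the estimated value is 28000 nM, with an expected range of 9000 nM to 80000 nM.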

Compound 4, half-maximal inhibitory concentration: 40000 nM
Compound 4: middle estimate off by 1.4-fold (0.15 log units), on the low side, and the stated range covers the measured number.
By their numbers in this assay, from the lowest: compounds 2, 1 and 4 (each within the scatter of the next). At a limit, above all of these: compound 3.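

In this assay, fluoro in place of chloro on the aromatic carbon gives a 1.3-fold higher number from compound 2 to compound 4 (0.12 log units; within the scatter), and fluoro in place of iodo at the same place gives no change at the digits printed from compound 1 to compound 4 (within the scatter). Where the earlier compounds offered a single exchange, three halogens can now be compared with one another at this position, and none of the three steps among them goes beyond the scatter. No order among compound 1, compound 2 and compound 4 can therefore be read, and no trend runs from iodo through chloro to fluoro.

Going by these compounds, whether any group at this position can move the number beyond the scatter remains open, since all the values here come from halogens; an amine, a carboxylic acid or a longer chain on the same aromatic carbon would put that question to the test. Compound 3 differs from the others by more than one place and holds only a limit rather than a number, so steps to it cannot be read: the limit of > 100000 nM in this assay, at which 1 of the 4 values shown sits.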